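A few compounds are considered here, and "the series" means these few. Any claim that something is new, unique, unknown or untested is made for them only; others in the source may bear on it.

Measured so far:
compound 1, `CC(C)/N=C(\NC1=NC(=O)CN1c1ccc(Cl)c(Cl)c1)Nc1ccc(Cl)c(Cl)c1`: 0.654 h
compound 2, `CC(C)N1CC(=O)N=C1N/C(=N\C(=O)C(C)(C)C)Nc1ccc(Cl)c(Cl)c1`: > 1 h (a limit)
compound 3, `CC(C)N1CC(=O)N=C1N/C(=N/c1ccc(Cl)c(Cl)c1)N1CCCCC1`: 0.467 h

Of the compounds shown here, three have been measured in an in vivo ADME assay on the whole organism for metabolic stability, with Homo sapiens as the target, read by LC-MS, at a dose of 160 mg/kg by the oral route; on this read-out higher numbers stand for a longer-lived compound and lower numbers for a shorter-lived compound. Compound 1 gives 0.654 h in this assay, and compound 3 gives 0.467 h. These two numbers lie within the usual scatter of each other, so neither can be placed above the other. For compound 2, this assay reports > 1 h, which is a limit of the assay and not a number.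

The step followed here leads from compound 3 to compound 4, `CC(C)N1CC(=O)N=C1N/C(=N/c1ccc(Cl)c(Cl)c1)N1CCCC1`, which has not yet been measured. The change is pyrrolidin-1-yl in place of piperidin-1-yl on a carbon with a double bond to nitrogen. For the measured compounds named here, no pair of measured compounds differs in just this way, so there is no measured step of this kind to lean on. The pyrrolidin-1-yl group takes the place of the piperidin-1-yl group with nothing else moved, and the expectation is that such a step stays within the usual scatter in this assay, in no firm direction; the expected step is a 1.0-fold lower number from compound 3 to compound 4 (0.02 log units; within the scatter). Compound 4 is therefore estimated at 0.45 h, with a range from 0.25 h to 0.9 h.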

Compound 4, half-life: > 1 h
Compound 4: no number, only a limit; the forecaster's own chance of this, stated with the estimate: 5%; at least 2.2-fold (0.34 log units) between middle value and limit.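

In this assay putting pyrrolidin-1-yl in place of piperidin-1-yl on a carbon with a double bond to nitrogen gives an at least 2.1-fold higher number from compound 3 to compound 4 (0.33 log units; beyond the scatter) and so shows that this one ring, with the rest of the compound unchanged, can shift the half-life beyond the scatter. The earlier compounds could not show this, since no two of them differed in one place, and this remains the only step that can be read among the compounds shown. From the compounds shown here alone, compound 4 gives > 1 h as a limit of the assay and not a number, and the full size of the step stays unknown because the read-out stops there: the limit of > 1 h in this assay, at which 2 of the 4 values shown sit.

Going by these compounds, it remains open whether other groups on this carbon, such as azetidin-1-yl, morpholin-4-yl or an open-chain dimethylamino group, would give a half-life nearer that of the pyrrolidin-1-yl or the piperidin-1-yl compound. It is also open whether the same exchange of rings would give a step of this kind in a compound that differs elsewhere, for instance one carrying a longer chain in place of the isopropyl group.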